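Notes on compound 1 and the fluoro analogue compound 4

The source may hold more compounds than are shown below. What is called first, only, known or untested is meant among the compounds shown, and "the series" means these compounds.

Measured so far:
compound 1, `CC(C)(C)c1ccc(/C=C/C(=O)c2ccc(OCC(=O)N[C@H]3CCOC3=O)cc2)cc1`: 10600 nM
compound 2, `O=C(CNc1ccccc1)N[C@H]1CCOC1=O`: > 64000 nM
compound 3, `C=CCc1ccc(OCCSC(=S)N[C@H]2CCOC2=O)c(OC)c1`: > 64000 nM

Among the compounds with values here, in a functional assay on PC-3 cells (Homo sapiens) for antiproliferative activity, read by MTT assay, with a stated time of 72 h (on this read-out lower numbers stand for stronger inhibition and higher numbers for weaker inhibition), compound 1 gives 10600 nM, and this is the only value in the set that is read as a number. For compound 2 the read-out is a limit of the assay, > 64000 nM. For compound 3 the read-out is likewise a limit, > 64000 nM. Within the data shown here, the set therefore sits largely at the limit of > 64000 nM in this assay, at which 2 of the 3 values shown sit, with compound 1 as the single measurable point and no step between measured compounds available to calibrate the effect of any single change.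

Compound 4, `O=C(COc1ccc(C(=O)/C=C/c2ccc(F)cc2)cc1)N[C@H]1CCOC1=O`, awaits measurement in this assay. Against compound 1 the change is fluoro in place of tert-butyl on an aromatic carbon; cut one bond further out it reads 4-(tert-butyl)phenyl to 4-fluorophenyl, the rest of the shared core being unchanged. With no measured step of this kind in the series, the working expectation in this assay is a step no larger than the usual scatter, leaning if anything toward weaker inhibition, a shift estimated as a 1.5-fold higher number from compound 1 to compound 4 (0.18 log units; within the scatter). Compound 4 is accordingly expected to give about 16000 nM, within a range of 5000 nM to 50000 nM, with some chance that only a limit is reported.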

Compound 4, half-maximal inhibitory concentration: 15600 nM
For compound 4 the middle estimate is 1.0-fold (0.01 log units) above the measured one; low and high end bracket the measured number.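

Within the data shown here, at this position, on an aromatic carbon of a six-membered aromatic ring of carbon only, para to a large group, this assay gives the first measured step: a 1.5-fold higher number from compound 1 to compound 4 (0.17 log units; within the scatter). The tert-butyl group, with its 4 heavy atoms, thus gives way to the single fluorine of the fluoro group without a shift that can be told from the scatter, so the measurable read-out does not depend on keeping tert-butyl here. The shared core of compound 1 and compound 4 now carries two measurable values, while the remaining compounds are read only as a limit: the limit of > 64000 nM in this assay, at which 2 of the 4 values shown sit.

As far as these compounds go, whether this position tolerates any group equally remains open, since an amine, a carboxylic acid or a longer alkyl chain in place of the fluoro could still move the number beyond the scatter, and two substituents cannot define a trend. Among these compounds, with only this one change in view, the contribution of the rest of the shared core, including the part that carries the amide, cannot be read from these values.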